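Notes toward compound 3: 1H-pyrazol-4-yl in place of 2,6-difluorophenyl

A few compounds are considered here, and "the series" means these few. Any claim that something is new, unique, unknown or untested is made for them only; others in the source may bear on it.

Compound 1 `CC(C)Cc1csc(N)c1C(=O)c1ccc(Cl)cc1` and compound 2 `CC(C)(C)Cc1c(-c2c(F)cccc2F)sc(N)c1C(=O)c1ccc(Cl)cc1` share one core. In an assay on CHO cells for displacement of a labelled ligand from adenosine receptor A3 (Homo sapiens), read by scintillation counting, tested at 10 uM (a lower number here means less inhibition, a higher number more inhibition at the concentration tested (going by the name of the read-out)), compound 1 gives 1%. In this assay compound 2 gives 1%, level with compound 1 within the scatter. Compound 3 `CC(C)(C)Cc1c(-c2cn[nH]c2)sc(N)c1C(=O)c1ccc(Cl)cc1` differs from compound 2 by 1H-pyrazol-4-yl in place of 2,6-difluorophenyl on an aromatic carbon. Going by the values given here, no step between measured compounds is available here. Given that compound 2 gives 1%, the step expected for compound 3 is a number 1 percentage points higher from compound 2 to compound 3 (within the scatter), no change beyond the scatter in either direction. Compound 3 is estimated at 2% in this assay, with a range from -8% to 14%.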

Compound 3, a percentage reported as inhibition, at one concentration (the size of the read-out at that concentration, not a potency): 1%
For compound 3 the middle estimate is 1 percentage points above the measured one, within the range that was stated.
By their numbers in this assay, from the lowest: compounds 1, 2 and 3 (each within the scatter of the next).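

In this assay, 1H-pyrazol-4-yl in place of 2,6-difluorophenyl on the aromatic carbon next to the ring sulfur gives no change at the digits printed from compound 2 to compound 3 (within the scatter), the first step read at this position. The read-out at this one concentration therefore does not separate these two aromatic rings, despite the hydrogen-bond donor and acceptor that enter with the pyrazole. No supporting measurement bears on this result. Still open, from the compounds shown here alone, is whether a carboxylic acid or a piperidin-4-yl at this position would move the inhibition. Also open, going by these compounds, is whether a change at the neopentyl group or the 4-chlorophenyl carbonyl group would do so.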